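Fluoro-to-chloro swap on the ethyl chain of compound 1

The compounds below may be only part of what the source reports. "The series", "measured", "known", "first", "only" and "open" are said of these compounds alone.

Measured compounds:
- compound 1 `COc1nc(C)c(CCF)c(OC)n1`: in a functional assay on SW-620 cells (Homo sapiens) for antiproliferative activity, read by MTT assay, with a stated time of 24 h (on this read-out lower numbers stand for stronger inhibition and higher numbers for weaker inhibition), compound 1 gives > 100000 nM, a limit of the assay.
- compound 2 `COc1nc(Cl)nc(C)c1CCF`: in this assay compound 2 gives > 100000 nM, a limit of the assay.
- compound 3 `COc1nc(Cl)nc(C)c1CCOC(C)=O`: in this assay compound 3 gives > 100000 nM, a limit of the assay.

Compound 1 stands at a limit only, with no number to place it against the other two; the shown values all sit at the limit of > 100000 nM in this assay, at which 3 of the 3 values shown sit. The step that the two limits leave unreadable from compound 1 to compound 2, chloro in place of methoxy on an aromatic carbon, and the step that the two limits leave unreadable from compound 2 to compound 3, acetoxy in place of fluoro on a saturated chain carbon, two bonds along the chain from an aromatic carbon, are both hidden between limits and give no readable size.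

Compound 4 `COc1nc(C)c(CCCl)c(OC)n1` differs from compound 1 by chloro in place of fluoro on a saturated chain carbon, two bonds along the chain from an aromatic carbon. Within the data shown here, of the measured steps, only the one from compound 2 to compound 3 touches the same saturated chain carbon, and it is unreadable. Among the measured compounds shown here, no step in this assay is therefore available to set a direction, and the starting point is itself a limit. Compound 4 is expected to remain at the limit of this assay, which is the step of a number no higher from compound 1 to compound 4 (the limit leaves the size open). The estimate for compound 4 is 100000 nM, between 30000 nM and 300000 nM.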

Compound 4, half-maximal inhibitory concentration: > 100000 nM
Compound 4: a limit, no number; the forecaster's own chance of this, stated with the estimate: 85%; the middle value lies on the limit itself.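

In this assay, among these compounds, compound 4 gives > 100000 nM, a limit of the assay, and compound 1 also stands at a limit, so no step between the two can be read. The compounds shown leave open whether any change to the shared core gives a countable value: the limit of > 100000 nM in this assay, at which 4 of the 4 values shown sit.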